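Removing the Acetoxy Group: What to Expect

The source may report more compounds than this note shows. Statements on the series, on what has been measured and on what is new or still open speak of the compounds shown alone.

Compound 1 `Cc1nc2c(OCc3ccccc3)cccn2c1CS(C)(=O)=O` gives 61% in a functional assay on the whole organism with Rattus norvegicus as the target, with a stated time of 4 h, at a dose of 40 mg/kg by the intraperitoneal route; a higher number here means more inhibition at the dose given (going by the name of the read-out), a lower number less inhibition.
Compound 2 `Cc1nc2c(OCc3ccccc3)cccn2c1CC1=NCCN1` gives 69% in this assay.
Compound 3 `CC(=O)OCc1c(C)nc2c(OCc3ccccc3)cccn12` gives 88% in this assay.

Compound 3 stands highest of the three measured compounds: the step of a number 27 percentage points higher from compound 1 to compound 3 (beyond the scatter) and the step of a number 19 percentage points higher from compound 2 to compound 3 (beyond the scatter) both lie beyond the scatter, whereas a number 8 percentage points higher from compound 1 to compound 2 (within the scatter) does not. Compound 4 `Cc1nc2c(OCc3ccccc3)cccn2c1C` differs from compound 3 by hydrogen in place of acetoxy on a saturated chain carbon bound to an aromatic carbon. Among the compounds with values here, no measured step removes this group outright; the two steps leading to compound 3 only show that acetoxy gave more inhibition than methylsulfonyl or the five-membered non-aromatic ring group, each by a modest margin. A modest fall in this assay is therefore expected, a number 30 percentage points lower from compound 3 to compound 4 (beyond the scatter). Compound 4 is estimated at 58%, with a range from 32% to 82%.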

Compound 4, a percentage reported as inhibition, in the whole organism at one dose (the size of the read-out at that dose, not a potency): 99%
Beside the measured number, compound 4's estimate is 41 percentage points below it, and the stated range ends below it.
By their numbers in this assay, from the lowest: compounds 1 and 2 (each within the scatter of the next); then compound 3; then compound 4.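

Taking the chain down to a plain methyl gives the first view of this carbon without an added group, and in this assay the number rises (a number 11 percentage points higher from compound 3 to compound 4 (beyond the scatter)). The acetoxy group is therefore not required for inhibition at this dose, and the other two groups also fall short of hydrogen (a number 30 percentage points higher from compound 2 to compound 4 (beyond the scatter); a number 38 percentage points higher from compound 1 to compound 4 (beyond the scatter)). Nothing measured here explains this order. As far as these compounds go, whether an ethyl group, a hydroxymethyl group or an aminomethyl group on this carbon would keep the number this high remains open. From the compounds shown here alone, these are single-dose readings, so how the compounds compare in potency also remains open.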